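Vero cytotoxicity across the amide series, compound 4 pending

This account rests on a few compounds, and the source may have more. Where it says the series, first, only, none or still open, it means among the compounds named here.

In an ADME assay on Vero cells (Chlorocebus sabaeus) for cytotoxicity, read by resazurin assay, with a stated time of 3 days (on this read-out higher numbers stand for weaker inhibition and lower numbers for stronger inhibition), the measured compounds stand as follows:
compound 1 `CN(C)c1cc2[nH]c(C3CCCCC3)nc2cc1NC(=O)c1ccc(Br)cc1` gives > 100 ug/mL, a limit of the assay.
compound 2 `CCCCOC(=O)Nc1cc2nc(C3CCCCC3)[nH]c2cc1N(C)C` gives > 100 ug/mL, a limit of the assay.
compound 3 `CCCc1ccc(C(=O)Nc2cc3nc(C4CCCCC4)[nH]c3cc2N(C)C)cc1` gives > 100 ug/mL, a limit of the assay.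

Compound 3 stands where the other two stand, at the limit, and none of the three carries a number. The steps among them, a step that the two limits leave unreadable from compound 1 to compound 2, a step that the two limits leave unreadable from compound 1 to compound 3 and a step that the two limits leave unreadable from compound 2 to compound 3, are unreadable in size because of the limit of > 100 ug/mL in this assay, at which 3 of the 3 values shown sit. Compound 4 `CN(C)c1cc2[nH]c(C3CCCCC3)nc2cc1NC(=O)c1ccc(OC(F)F)cc1` is the next member and differs from compound 3 by difluoromethoxy in place of propyl on an aromatic carbon. No measured step bears on this change in a readable way: every step shown starts and ends at the limit. With nothing in this assay resolved beyond the scatter so far, no step beyond the scatter is expected. Compound 4 is accordingly expected to give 150 ug/mL in this assay, with a range from 50 ug/mL to 400 ug/mL, most probably reported again only as a limit. The step this estimate implies, a step that the limit leaves unreadable from compound 3 to compound 4, is expected to remain unreadable in the same way.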

Compound 4, half-maximal inhibitory concentration: > 100 ug/mL
Compound 4 gave a limit, no number; the forecaster's own chance of this, stated with the estimate: 85%; the middle value does not contradict the limit.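

The steps from compound 1, compound 2 and compound 3 to compound 4 cannot be read in this assay because all four compounds stand at the same limit: the limit of > 100 ug/mL in this assay, at which 4 of the 4 values shown sit.

Where this assay would give a number for any of these compounds stays open, and so does any difference between their groups.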